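Amino-triazole variant of a cyanoguanidine histamine antagonist

The compounds below may be only part of what the source reports. "The series", "measured", "known", "first", "only" and "open" are said of these compounds alone.

compound 1 `Cc1nc(CCCN/C(=N\C#N)NCCSc2ccccc2)c[nH]1`: < 5
compound 2 `N#C/N=C(\NCCCCc1cnn[nH]1)NCCSc1ccccc1`: < 5

In a functional assay on Sf9 cells for antagonist activity at histamine H2 receptor (Homo sapiens), read by scintillation counting and GTPgammaS binding, with a stated time of 90 min (on this read-out lower numbers stand for lower potency and higher numbers for higher potency (the scale is a negative logarithm)), compound 1 gives < 5, which is a limit of the assay and not a number. In this assay compound 2 gives < 5, again only a limit. The step that the two limits leave unreadable from compound 1 to compound 2 is therefore unreadable. Compound 3 `N#C/N=C(\NCCCCc1nc(N)n[nH]1)NCCSc1ccccc1` differs from compound 2 by 3-amino-1H-1,2,4-triazol-5-yl in place of 1H-1,2,3-triazol-5-yl on a saturated chain carbon, four bonds along the chain from an amine nitrogen. For the measured compounds named here, no measured step gives guidance on it, since (the limit of < 5 in this assay, at which 2 of the 2 values shown sit). The expected step of a number no lower from compound 2 to compound 3 (the limit leaves the size open) rests only on a limit. Compound 3 is estimated at 5, between 4.3 and 5.8, and is most likely to be reported again as a limit.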

Compound 3, negative logarithm of the antagonist equilibrium constant: < 5
Compound 3: a limit, no number (the forecaster's own chance of this, stated with the estimate: 60%); the middle value lies on the limit itself.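

No step among compound 1, compound 2 and compound 3 can be read in this assay: the limit of < 5 in this assay, at which 3 of the 3 values shown sit.

The compounds shown leave open whether 3-amino-1H-1,2,4-triazol-5-yl in place of 1H-1,2,3-triazol-5-yl changes potency at all.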